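The source may report more compounds than this note shows. Statements on the series, on what has been measured and on what is new or still open speak of the compounds shown alone.

Compound 2 `Cc1cccc(/C(N)=N/NC(=S)N2CCCC2)n1` and compound 1 `Cc1ccnc(/C(N)=N/NC(=S)N2CCCC2)c1` share one core and differ only in where the methyl sits. In a functional assay on HeLa cells (Homo sapiens) for cytotoxicity, read by MTT assay, with a stated time of 72 h, tested at 3 uM (on this read-out higher numbers stand for more inhibition of growth at the one concentration tested and lower numbers for less inhibition of growth), compound 2 gives 56.8%, while compound 1 gives 52.1%, and the two values lie within the scatter of each other, so neither stands apart. Compound 3 `N/C(=N\NC(=S)N1CCCC1)c1ccccn1` has not yet been tested in this assay. It differs from compound 2 by hydrogen in place of methyl on an aromatic carbon. Since compound 2 gives 56.8% and compound 1 gives 52.1% with the methyl in different places, its loss is expected to matter little. Compound 3 is estimated to give 50% in this assay, with a range of 35% to 65%. The step of a number 6.8 percentage points lower from compound 2 to compound 3 (within the scatter) is expected to stay within the scatter.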

Compound 3, percent growth inhibition at one concentration: 38.5%
Compound 3: the middle estimate sits 11.5 percentage points above what was measured; low and high end bracket the measured number.
By their numbers in this assay, from the lowest: compound 3; then compounds 1 and 2 (each within the scatter of the next).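

Dropping the methyl is a real loss in this assay: the change gives a number 18.3 percentage points lower from compound 2 to compound 3 (beyond the scatter) and also a number 13.6 percentage points lower from compound 1 to compound 3 (beyond the scatter), so hydrogen in place of methyl on an aromatic carbon lowers growth inhibition from either of the two places. Where compound 1 and compound 2 showed only that the methyl's place makes no clear difference, compound 3 shows that its presence does. Nothing at hand explains this loss.

On these data alone, it remains open whether an ethyl group, a methoxy group or an amine at these places would match the methyl or exceed it. As far as these compounds go, whether a methyl at both places together would add further inhibition also remains open.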